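Removing one fluoro from the thiourea aryl: compound 2 to compound 3

The source may report more compounds than this note shows. Statements on the series, on what has been measured and on what is new or still open speak of the compounds shown alone.

Two members of the series carry a shared core, `CNC(=O)c1ccc(Oc2cccc(NC(=S)Nc3ccc(C)c(C)c3)c2)nc1` for compound 1 and `CNC(=O)c1ccc(Oc2cccc(NC(=S)Nc3ccc(F)c(F)c3)c2)nc1` for compound 2, differing only in the aryl on the thiourea nitrogen. In a functional assay on HepG2 cells (Homo sapiens) for antiproliferative activity, read by MTT assay (a lower number here means a stronger inhibitor, a higher number a weaker inhibitor), compound 1 reaches only a limit, > 100000 nM, so no number is available for it. In this assay, going by the values given here, compound 2 gives 26700 nM, the only number in the set. Among the compounds with values here, the one step that can be read is an at least 3.7-fold lower number from compound 1 to compound 2 (0.57 log units; beyond the scatter). Because the value for compound 1 is the limit of > 100000 nM in this assay, at which 1 of the 2 values shown sits, only the smallest possible size of that step is known.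

Compound 3, `CNC(=O)c1ccc(Oc2cccc(NC(=S)Nc3ccc(F)cc3)c2)nc1`, is the next variation: hydrogen in place of fluoro on an aromatic carbon. Within the data shown here, no measured pair covers removal of a single fluoro, so the only relevant evidence is that the fluoro pair in compound 2 gave a better number than the methyl pair in compound 1, and compound 3 keeps one of the two fluoro groups. Compound 3 is expected to show a step of a 1.3-fold higher number from compound 2 to compound 3 (0.12 log units; within the scatter). The estimate for compound 3 in this assay is 35000 nM, with a range from 12000 nM to 100000 nM.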

Compound 3, half-maximal inhibitory concentration: 42500 nM
Compound 3: middle estimate off by 1.2-fold (0.08 log units), on the low side; low and high end bracket the measured number.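

In this assay, going from 3,4-difluorophenyl to 4-fluorophenyl on the thiourea nitrogen gives a 1.6-fold higher number from compound 2 to compound 3 (0.20 log units; within the scatter), so at this position hydrogen in place of fluoro leaves no change that can be told apart from repeat scatter. Set against the dimethyl aryl, the 4-fluorophenyl compound shows an at least 2.3-fold lower number from compound 1 to compound 3 (0.37 log units; beyond the scatter), which places both fluoro-bearing compounds on the same side of compound 1 and shows that the second fluoro is not needed for that separation. Only the smallest possible size of this step is known because compound 1 stands at a limit, not a number: the limit of > 100000 nM in this assay, at which 1 of the 3 values shown sits.

Still open, from the compounds shown here alone, is whether the remaining fluoro contributes at all, a question that an unsubstituted phenyl would settle, and whether a single methyl, a chloro or a methoxy group on the same ring would stay with the fluoro compounds or fall with the dimethyl compound. The rest of the shared core is also untested in these compounds, including the effect of a urea oxygen in place of the thiourea sulfur or of a longer chain in place of the methyl on the amide nitrogen.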